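This account rests on a few compounds, and the source may have more. Where it says the series, first, only, none or still open, it means among the compounds named here.

Compound 1 `O=C(NCCCn1ccnc1)c1cc2ccccc2s1` gives 36000 nM
Compound 2 `Cc1ccsc1C(=O)NCCCn1ccnc1` gives > 276000 nM (a limit)
Compound 3 `Cc1ccc(C(=O)NCCCn2ccnc2)s1` gives > 320000 nM (a limit)

All three compounds were tested in a functional assay on MDA-MB-231 cells (Homo sapiens) for cytotoxicity, read by MTT assay, with a stated time of 72 h; on this read-out higher numbers stand for weaker inhibition and lower numbers for stronger inhibition. Compound 3 has no exact number on this read-out, only a limit: > 320000 nM. Compound 2 also has only a limit: > 276000 nM. Compound 1 is the only one of the three with an exact value, 36000 nM, so the amide side chain shared by these compounds can give a measurable result in this assay.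

Compound 4 `O=C(NCCCn1ccnc1)c1ccc([N+](=O)[O-])s1` differs from compound 3 at one place: nitro in place of methyl on an aromatic carbon, next to the ring sulfur (nitro in place of methyl on an aromatic carbon). Among the compounds with values here, no measured pair here shows what this exchange does, so any forecast is loose. A move towards stronger inhibition is expected, but a modest one, and the assay may again report only a limit. The expected change is an at least 2.6-fold lower number from compound 3 to compound 4 (0.42 log units; beyond the scatter). Compound 4 is estimated at 120000 nM, with an expected range from 25000 nM to 400000 nM.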

Compound 4, half-maximal inhibitory concentration: > 390000 nM
Compound 4: a limit, no number (the forecaster's own chance of this, stated with the estimate: 35%); middle value at least 3.2-fold (0.51 log units) away from the limit.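

Compound 3 and compound 4 both have only a limit in this assay, not an exact number, so the step between them cannot be read. The compounds shown leave open whether nitro in place of methyl on an aromatic carbon changes the result in this assay at all, and if it does, in which direction and by how much.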